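Phenyl to furan-2-yl on compound 2

The compounds below may be only part of what the source reports. "The series", "measured", "known", "first", "only" and "open" are said of these compounds alone.

In a functional assay on PC-3 cells (Homo sapiens) for antiproliferative activity (a higher number here means a weaker inhibitor of growth, a lower number a stronger inhibitor of growth), compound 1 `c1ccc(-c2cc(-c3ccsc3)cc(-c3ccccn3)n2)nc1` gives 0.0017 ug/mL and compound 2 `c1ccc(-c2cc(-c3ccccn3)nc(-c3ccccn3)c2)cc1` gives 0.017 ug/mL. Compound 2 therefore holds the higher of the two numbers, the weaker growth inhibition of the pair. Compound 3 `c1ccc(-c2cc(-c3ccco3)cc(-c3ccccn3)n2)nc1` carries furan-2-yl in place of phenyl on an aromatic carbon, opposite the ring nitrogen (furan-2-yl in place of phenyl on an aromatic carbon). Among the measured compounds shown here, one measured step bears on this change: a 10-fold higher number from compound 1 to compound 2 (1.00 log units; beyond the scatter), beyond the scatter, with phenyl in place of thiophen-3-yl. Read in reverse, that step points to a lower number when phenyl leaves. No furan-2-yl value exists yet, and a single step is thin support, so a somewhat smaller change is expected in this assay. The expected move is a 3.4-fold lower number from compound 2 to compound 3 (0.53 log units; beyond the scatter), towards stronger inhibition. For compound 3 the estimated value is 0.005 ug/mL, with an expected range of 0.001 ug/mL to 0.025 ug/mL.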

Compound 3, concentration for 50% growth inhibition: 0.0025 ug/mL
The estimate for compound 3 lay 2.0-fold (0.30 log units) above the measured number, and the stated range covers the measured number.
By their numbers in this assay, from the lowest: compounds 1 and 3 (each within the scatter of the next); then compound 2.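

In this assay, with furan-2-yl at the position opposite the ring nitrogen there is a 6.8-fold lower number from compound 2 to compound 3 (0.83 log units; beyond the scatter) and so a second five-membered ring, after thiophen-3-yl, gives a lower number than phenyl. Among the compounds shown here, the comparison of the two five-membered rings gives a 1.5-fold higher number from compound 1 to compound 3 (0.17 log units; within the scatter) and so does not separate furan-2-yl from thiophen-3-yl, leaving phenyl as the only one of the three groups set apart by its number. No measured evidence on hand accounts for this difference. 

The compounds shown leave open whether this position tolerates a group without an aromatic ring, such as a short alkyl chain, an amine or a carboxylic acid. They also leave open how furan-3-yl and thiophen-2-yl would compare, and so whether the point of attachment of the five-membered ring matters.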